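Swapping an aryl group for a short hydroxyalkyl chain

The source may report more compounds than this note shows. Statements on the series, on what has been measured and on what is new or still open speak of the compounds shown alone.

Compound 1, `COc1nc2ccc(Br)cc2cc1C(c1ccccc1)n1cc(C2CC2)nn1`, gives 3.52% in an ADME assay on SK-OV-3 cells (Homo sapiens) for cytotoxicity, read by sulforhodamine B assay, with a stated time of 48 h, tested at 10 uM; a lower number here means less inhibition, a higher number more inhibition at the concentration tested (going by the name of the read-out).
Compound 2, `COc1nc2ccc(Br)cc2cc1C(c1ccccc1)n1cc(-c2ccc(Br)cc2)nn1`, gives 13.4% in this assay.
Compound 3, `COc1nc2ccc(Br)cc2cc1C(c1ccccc1)n1cc(-c2ccc(OC(F)(F)F)cc2)nn1`, gives 14.8% in this assay.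

Among these three numbers compound 3 stands highest, though its difference from compound 2 lies within the scatter; only the gap to compound 1 is beyond it. Compound 4, `COc1nc2ccc(Br)cc2cc1C(c1ccccc1)n1cc(CCCO)nn1`, differs from compound 3 by 3-hydroxypropyl in place of 4-(trifluoromethoxy)phenyl on an aromatic carbon. The step that bears on this is the one from cyclopropyl to an aryl group, a number 11.3 percentage points higher from compound 1 to compound 3 (beyond the scatter); the parallel step a number 9.9 percentage points higher from compound 1 to compound 2 (within the scatter) points the same way but stays within the scatter, and a number 1.4 percentage points higher from compound 2 to compound 3 (within the scatter) shows the two aryl groups behave alike. Replacing the aryl group by a chain is expected to undo that rise, so a modest fall a number 9.8 percentage points lower from compound 3 to compound 4 (within the scatter) is expected in this assay. Compound 4 is therefore estimated at 5%, within -5% to 15%.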

Compound 4, a percentage reported as inhibition, at one concentration (the size of the read-out at that concentration, not a potency): 13.8%
Estimate against measurement, compound 4: 8.8 percentage points below; measured number inside the range.
By their numbers in this assay, from the lowest: compounds 1, 2, 4 and 3 (each within the scatter of the next, the first and the last beyond it).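

In this assay, the 3-hydroxypropyl chain matches both aryl groups, a number 1 percentage points lower from compound 3 to compound 4 (within the scatter) and a number 0.4 percentage points higher from compound 2 to compound 4 (within the scatter), so an aromatic ring at this carbon is not required to reach this level. Against cyclopropyl, the chain gives a number 10.3 percentage points higher from compound 1 to compound 4 (beyond the scatter), so the rise seen with 4-(trifluoromethoxy)phenyl also appears with a group that has no ring. Nothing available explains why such different groups give such similar numbers. Still open, on these data alone, is whether a longer chain would behave the same way, or a chain ending in an amine or a carboxylic acid instead of a hydroxyl.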